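The source may report more compounds than this note shows. Statements on the series, on what has been measured and on what is new or still open speak of the compounds shown alone.

Measured so far:
Compound 1, `CC1=NC(C)=C(C(=O)O)C(c2ccc([N+](=O)[O-])cc2)/C1=C(\O)OC/C=C/c1ccccc1`, gives 1600 nM in a functional assay on thoracic aorta for inhibition of Voltage-gated L-type calcium channel (Rattus norvegicus); on this read-out lower numbers stand for stronger inhibition and higher numbers for weaker inhibition.
Compound 2, `CC1=NC(C)=C(C(=O)O)C(c2cccc(C(=O)O)c2)/C1=C(\O)OC/C=C/c1ccccc1`, gives in this assay only a limit of the assay, > 10000 nM.

Going by the values given here, compound 1 therefore holds the only real number among the two values shown; the other value is a limit, (the limit of > 10000 nM in this assay, at which 1 of the 2 values shown sits), and says only that compound 2 is weaker than that mark.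

Compound 3, `CC1=NC(C)=C(C(=O)O)C(c2ccsc2)/C1=C(\O)OC/C=C/c1ccccc1`, is not yet measured. It differs from compound 1 in one place: thiophen-3-yl in place of 4-nitrophenyl on a saturated ring carbon.

Among the compounds with values here, only one measured step touches the same place. Exchanging the 4-nitrophenyl for a 3-carboxyphenyl gave an at least 6.2-fold higher number from compound 1 to compound 2 (0.79 log units; beyond the scatter), so a change of the group on that saturated ring carbon can cost potency clearly. The thiophen-3-yl of compound 3 is a different replacement, so that step is only a rough guide. A small to modest weakening is expected, with a real chance that the change stays within the scatter.

Compound 3 is estimated to give about 3500 nM in this assay, between 1200 nM and 10000 nM. This estimate means an expected step of a 2.2-fold higher number from compound 1 to compound 3 (0.34 log units; beyond the scatter).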

Compound 3, half-maximal inhibitory concentration: 44 nM
Compound 3: the middle estimate sits 80-fold (1.90 log units) above what was measured; the whole stated range lies above it.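

The group on this saturated ring carbon can move the read-out in this assay strongly towards stronger inhibition, and not only towards weaker inhibition: thiophen-3-yl in place of 4-nitrophenyl gives a 36-fold lower number from compound 1 to compound 3 (1.56 log units; beyond the scatter). Set against the 3-carboxyphenyl, the same thiophen-3-yl gives an at least 220-fold lower number from compound 2 to compound 3 (2.35 log units; beyond the scatter), so the three groups compared here span a wide range of potency through a change at this one place on an otherwise unchanged core. The weak end of that range has no real number, as compound 2 gives only a limit of the assay: the limit of > 10000 nM in this assay, at which 1 of the 3 values shown sits.

The compounds shown leave open whether the gain belongs to the five-membered thiophene ring with its sulfur or simply to a group with fewer heavy atoms than 4-nitrophenyl, and a plain phenyl, a thiophen-2-yl or a furan-3-yl at the same carbon would help to separate these readings. They also leave open how much the carboxy group on the neighbouring ring atom contributes, which a methyl ester in its place would address.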